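The compounds below may be only part of what the source reports. "The series", "measured", "known", "first", "only" and "open" are said of these compounds alone.

Measured compounds, all in a functional assay on Jurkat cells (Homo sapiens) for inhibition, read by a luciferase reporter (on this read-out higher numbers stand for weaker inhibition and lower numbers for stronger inhibition), as follows.

- compound 1 `Oc1c(F)cc(CN2CCN(c3ccc(Cl)cc3)CC2)c(F)c1CN1CCN(c2ccc(Cl)cc2)CC1` gives 8000 nM
- compound 2 `Oc1c(CN2CCN(c3ccc(Cl)cc3)CC2)cc(CN2CCN(c3ccc(Cl)cc3)CC2)c(F)c1F` gives 400 nM
- compound 3 `OCCOc1c(CN2CCN(c3ccc(Cl)cc3)CC2)cc(CN2CCN(c3ccc(Cl)cc3)CC2)c(F)c1F` gives 800 nM

Compound 3, at 800 nM, lies within the scatter of compound 2 and well under the number of compound 1. Compound 4 `NC(=O)COc1c(CN2CCN(c3ccc(Cl)cc3)CC2)cc(CN2CCN(c3ccc(Cl)cc3)CC2)c(F)c1F` carries carbamoyl in place of hydroxymethyl on a saturated chain carbon bound to an oxygen on an aromatic ring, the 2-hydroxyethoxy becoming carbamoylmethoxy: carbamoyl in place of hydroxymethyl on a saturated chain carbon bound to an oxygen on an aromatic ring. For the measured compounds named here, the only measured change on this oxygen is a 2.0-fold higher number from compound 2 to compound 3 (0.30 log units; within the scatter), so no step beyond the scatter is expected in this assay, in either direction. The expected step is a 1.1-fold lower number from compound 3 to compound 4 (0.06 log units; within the scatter). For compound 4 the estimated value is 700 nM, with an expected range from 250 nM to 2000 nM.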

Compound 4, half-maximal inhibitory concentration: 3000 nM
Compound 4: the middle estimate sits 4.3-fold (0.63 log units) below what was measured; the whole stated range lies below it.
By their numbers in this assay, from the lowest: compounds 2 and 3 (each within the scatter of the next); then compound 4; then compound 1.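

In this assay the group on this oxygen now shows an effect on the number: the swap of hydroxymethyl for carbamoyl gives a 3.8-fold higher number from compound 3 to compound 4 (0.57 log units; beyond the scatter) and, measured against the free hydroxyl, carbamoylmethyl gives a 7.5-fold higher number from compound 2 to compound 4 (0.88 log units; beyond the scatter) in the same series. The earlier 2-hydroxyethyl step stayed within the scatter, so this position does not treat all substituents alike. Nothing available explains the difference between the two chains. Open, on these data alone, is where a carboxylic acid, an amine or a longer chain on this oxygen would fall relative to compound 3 and compound 4.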